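The compounds below may be only part of what the source reports. "The series", "measured", "known", "first", "only" and "open" are said of these compounds alone.

Working notes on the series. Compound 1 `Cn1ncnc1-c1ccccc1NCC1=NCCN1` gives 2 nM in an in vitro functional assay on cells (Fibroblast) for agonist activity at Alpha-1A adrenergic receptor (Homo sapiens) (a lower number here means that less compound is needed, a higher number that more compound is needed for the effect), the lowest number of the three measured. Compound 3 `CC(C)n1ncnc1-c1ccccc1NCC1=NCCN1` gives 6.31 nM and compound 2 `CCCCn1ncnc1-c1ccccc1NCC1=NCCN1` gives 200 nM. Every measured step varies only the group on the aromatic nitrogen: a 3.2-fold higher number from compound 1 to compound 3 (0.50 log units; beyond the scatter), a 100-fold higher number from compound 1 to compound 2 (2.00 log units; beyond the scatter), and a 32-fold lower number from compound 2 to compound 3 (1.50 log units; beyond the scatter). Compound 4 `Cn1ccc(-c2ccccc2NCC2=NCCN2)n1` departs from compound 1 in a different way: 1-methyl-1H-pyrazol-3-yl in place of 1-methyl-1H-1,2,4-triazol-5-yl on an aromatic carbon. Among the compounds with values here, no measured step changes the ring itself, so the three steps do not bear directly on this change; the methyl on the aromatic nitrogen, as in compound 1, is retained. A step of modest size is expected in this assay, direction uncertain, so a 3.0-fold higher number from compound 1 to compound 4 (0.48 log units; beyond the scatter). Compound 4 is therefore estimated at 6 nM, within the range 1.5 nM to 30 nM.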

Compound 4, half-maximal effective concentration: 3.16 nM
Estimate against measurement, compound 4: 1.9-fold (0.28 log units) above; the range from low to high includes it.
By their numbers in this assay, from the lowest: compounds 1, 4 and 3 (each within the scatter of the next, the first and the last beyond it); then compound 2.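

The ring swap on the aromatic carbon gives a 1.6-fold higher number from compound 1 to compound 4 (0.20 log units; within the scatter) in this assay and so stays within the scatter, with 2 hetero atoms in the ring in place of 3. Where the earlier steps varied only the group on the aromatic nitrogen, this step shows that the ring itself can change here with the methyl retained. No measured property bears on this result.

Open, from the compounds shown here alone, is whether isopropyl or butyl on the pyrazole nitrogen would give steps like those on the triazole. Also open, going by these compounds, is how a pyridine ring or an amide would fare at this place.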